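Working notes: a second chloro on compound 2

A few compounds are considered here, and "the series" means these few. Any claim that something is new, unique, unknown or untested is made for them only; others in the source may bear on it.

Measured in a functional assay on L1210 cells (Mus musculus) for antiproliferative activity, with a stated time of 48 h; a lower number here means a stronger inhibitor, a higher number a weaker inhibitor:
- compound 1 `C=C(Br)C(=O)Nc1ccc(/C=C/C(=O)c2ccc(Cl)c(Cl)c2)cc1`: 2100 nM
- compound 2 `Nc1ccc(/C=C/C(=O)c2ccc(Cl)cc2)cc1`: 111000 nM

Of the two measured compounds, compound 2 has the higher number, at 111000 nM, and so is the weaker inhibitor. Compound 1 gives 2100 nM, and the gap between the two lies beyond the scatter.

Compound 3 `Nc1ccc(/C=C/C(=O)c2ccc(Cl)c(Cl)c2)cc1` has not yet been measured in this assay. It follows from compound 2 by one change: chloro in place of hydrogen on an aromatic carbon, ortho to a chloro group.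

Among the measured compounds shown here, no measured pair isolates this change, so the data give no direct size for it. The two values alone do not show what a single chloro does here. A modest step towards a lower number is expected, and it may stay within the scatter. The gap down to compound 1 at 2100 nM is not expected to be closed.

The estimated step is a 2.0-fold lower number from compound 2 to compound 3 (0.30 log units; within the scatter). For compound 3 the expected value is 55000 nM, with an estimated range of 18000 nM to 130000 nM.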

Compound 3, half-maximal inhibitory concentration: 26000 nM
Compound 3: middle estimate off by 2.1-fold (0.33 log units), on the high side; measured number inside the range.
By their numbers in this assay, from the lowest: compound 1; then compound 3; then compound 2.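

In this assay, the chloro in place of hydrogen, ortho to a chloro group and meta to a large group, now has a size of its own: a 4.3-fold lower number from compound 2 to compound 3 (0.63 log units; beyond the scatter), so this position on the aromatic ring responds to the addition of a single chlorine atom. The same new compound also isolates the substituent on the nitrogen, which the earlier pair could not do, since they differ in two places: replacing (1-bromoethenyl)carbonyl with hydrogen gives a 12-fold higher number from compound 1 to compound 3 (1.09 log units; beyond the scatter), so this change carries the larger of the two steps. No measurement of any property bears on either step, and the data offer no explanation for them.

The compounds shown leave open whether the chloro step carries over to compounds that hold (1-bromoethenyl)carbonyl on the nitrogen, so the two steps cannot yet be treated as additive. Also open, as far as these compounds go, are whether a fluoro, methyl or methoxy group at the same ring position would give a step like that of chloro, and whether a plain acetyl group on the nitrogen would match (1-bromoethenyl)carbonyl.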